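A chloro on the aromatic ring of compound 2

This account rests on a few compounds, and the source may have more. Where it says the series, first, only, none or still open, it means among the compounds named here.

Among the compounds with values here, in a functional assay on the whole organism with Mus musculus as the target (on this read-out higher numbers stand for an effect only at larger amounts of compound and lower numbers for an effect already at smaller amounts), compound 2 `CCn1c(-c2ccccc2)nn(C)c1=S` gives 0.58 mg/kg, the higher of the two numbers measured so far. Within the data shown here, compound 3 `Cn1nc(-c2ccccc2)n(C)c1=S` gives 0.15 mg/kg, and a 3.9-fold lower number from compound 2 to compound 3 (0.59 log units; beyond the scatter) is the only step measured between compounds that differ in one place. That step lies beyond the scatter, but it concerns a saturated chain carbon bound to an aromatic nitrogen, so it bears on the present change only indirectly, as a guide to size.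

Compound 4 `CCn1c(-c2ccc(Cl)cc2)nn(C)c1=S` departs from compound 2 through (chloro in place of hydrogen on an aromatic carbon), with chloro in place of hydrogen on an aromatic carbon. Among the measured compounds shown here, no measured step makes this change alone. Compound 1 `CCCn1c(-c2ccc(Cl)cc2)nn(C)c1=S` also bears the chloro, with propyl in place of ethyl, and gives > 12.5 mg/kg, which is a limit and not a number. With compound 1 at > 12.5 mg/kg, a higher number is expected for compound 4 in this assay. The size expected is modest and is taken from a 3.9-fold lower number from compound 2 to compound 3 (0.59 log units; beyond the scatter), read in the opposite direction. The estimated change is a 4.0-fold higher number from compound 2 to compound 4 (0.60 log units; beyond the scatter). Compound 4 is expected to give 2.3 mg/kg, within an estimated range from 0.6 mg/kg to 11 mg/kg.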

Compound 4, dose for half-maximal effect: > 50 mg/kg
Compound 4 was reported as a limit (the forecaster's own chance of this, stated with the estimate: 15%); middle value at least 21-fold (1.33 log units) away from the limit.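

Within the data shown here, with the ethyl held in place, chloro in place of hydrogen on an aromatic carbon, para to a group of 9 heavy atoms, gives an at least 86-fold higher number from compound 2 to compound 4 (1.93 log units; beyond the scatter) in this assay, a large step and the first one-place reading of this change. For compound 4, > 50 mg/kg is a limit of the assay and not a number. Compound 1 had carried the chloro together with a propyl, so it could not separate the two groups; the high number now attaches to the chloro alone, while the step between compound 1 and compound 4 cannot be read, and nothing shown gives a measured property that would account for the chloro step.

As far as these compounds go, whether the sharp rise in the number belongs to chloro in particular stays open, since a fluoro, a methoxy or an amine at the same place would each have to be compared with the hydrogen of compound 2. Also open is whether the chloro has a step of similar size on the methyl-bearing compound 3, the lowest number shown.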